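This account rests on a few compounds, and the source may have more. Where it says the series, first, only, none or still open, it means among the compounds named here.

Measured compounds:
Compound 1, `O=C(/C=C/c1ccc2c(c1)B(O)OC2)c1ccc(I)cc1`: > 10 ug/mL
Compound 2, `COc1ccc(C(=O)/C=C/c2ccc3c(c2)B(O)OC3)cc1OC`: > 10 ug/mL

Both compounds were tested in an ADME assay on L929 cells (Mus musculus) for cytotoxicity, read by resazurin assay, with a stated time of 72 h (on this read-out higher numbers stand for weaker inhibition and lower numbers for stronger inhibition), a test of how much of a substance is needed to harm ordinary mouse cells. In this assay compound 2 gives > 10 ug/mL, which is a limit of the test rather than a measured number. Compound 1 likewise gives only a limit, > 10 ug/mL. So compound 2 stands at the same limit as the one other value shown, and nothing sets the two apart: the limit of > 10 ug/mL in this assay, at which 2 of the 2 values shown sit. Compound 3, `COc1cc(C(=O)/C=C/c2ccc3c(c2)B(O)OC3)cc(OC)c1OC`, has not yet been tested in this assay. It differs from compound 2 in one spot: methoxy in place of hydrogen on an aromatic carbon. The new methoxy sits ortho to a methoxy group and meta to another methoxy group on the same ring. For the measured compounds named here, since neither measured compound reached a number, there is no measured step to build on. The step from compound 2 to compound 3 is expected to be a step that the limit leaves unreadable from compound 2 to compound 3, that is none beyond the usual scatter. Compound 3 is therefore expected to give about 20 ug/mL, somewhere between 8 ug/mL and 50 ug/mL, most likely again reported only as a limit.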

Compound 3, half-maximal inhibitory concentration: > 10 ug/mL
Compound 3 was reported as a limit; the forecaster's own chance of this, stated with the estimate: 80%; the middle value is on the limit's open side.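

In this assay compound 3 gives > 10 ug/mL, a limit of the test and not a number. Compound 2 also stands at a limit, and no step can be read between compound 2 and compound 3. All the compounds shown share one result: the limit of > 10 ug/mL in this assay, at which 3 of the 3 values shown sit. What they leave open is what concentration of any of them would harm these cells, and whether the added methoxy changes that.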